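A few compounds are considered here, and "the series" means these few. Any claim that something is new, unique, unknown or untested is made for them only; others in the source may bear on it.

Measured compounds:
compound 1, `COc1ccc2ncc(S(=O)(=O)c3ccc(OC)c(Cl)c3)c(N3CCC(C)CC3)c2c1`, 21%
compound 2, `Cc1ccc(S(=O)(=O)c2cnc3ccc(F)cc3c2N2CCC(C)CC2)cc1C`, 92%
compound 3, `Cc1ccc(S(=O)(=O)c2cnc3ccc(F)cc3c2N2CCC(C)CC2)cc1Cl`, 91%

In an assay on isolated protein for displacement of a labelled ligand from metabotropic glutamate receptor 5 (Homo sapiens), with a stated time of 60 min, tested at 1 uM (a lower number here means less inhibition, a higher number more inhibition at the concentration tested (going by the name of the read-out)), compound 1 stands lowest of the three numbers. Its nearest neighbour is compound 3, whose value in this assay is far higher, beyond the scatter, and compound 2 lies a little further still. Within the data shown here, compounds 2 and 3 differ from compound 1 in more than one place, so their values show only that two related sulfonyl compounds reach high inhibition; no single step connects them to compound 1.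

Compound 4, `COc1ccc2ncc(S(=O)(=O)c3cccc(F)c3)c(N3CCC(C)CC3)c2c1`, is not yet measured. It differs from compound 1 by 3-fluorophenyl in place of 3-chloro-4-methoxyphenyl on a sulfonyl sulfur. Among the measured compounds shown here, the only measured step that touches a ring on the sulfonyl sulfur is a number 1 percentage points lower from compound 2 to compound 3 (within the scatter), a chloro in place of a methyl, and it changed nothing beyond the scatter. That step does not cover the loss of the methoxy group or a fluorine in place of chlorine, so the direction of the step into compound 4 is uncertain. Compound 2 reaches 92% and compound 3 reaches 91%, both without a methoxy group on the sulfonyl aryl ring. On that basis a rise in this assay is expected for compound 4, though with wide uncertainty. Compound 4 is estimated at 45%, ranging from 15% to 80%, which means an expected step of a number 24 percentage points higher from compound 1 to compound 4 (beyond the scatter).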

Compound 4, a percentage reported as inhibition, at one concentration (the size of the read-out at that concentration, not a potency): 68%
For compound 4 the middle estimate is 23 percentage points below the measured one; the range from low to high includes it.
By their numbers in this assay, from the lowest: compound 1; then compound 4; then compounds 3 and 2 (each within the scatter of the next).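

In this assay, putting 3-fluorophenyl in place of 3-chloro-4-methoxyphenyl on a sulfonyl sulfur gives a number 47 percentage points higher from compound 1 to compound 4 (beyond the scatter), so on the core of compound 1 the aryl group on this sulfur can by itself move the read-out by a large amount. Among these compounds, the earlier compounds offered only one step at this ring, a number 1 percentage points lower from compound 2 to compound 3 (within the scatter), a chloro in place of a methyl in a pair with other groups on the core, so they showed a change at this ring with no effect and this result shows that a change here can matter greatly. Nothing available explains the size of the new step.

This single step removes a chloro and a methoxy and brings in a fluorine all at once, so the compounds shown do not tell which of these changes accounts for the rise. Also open, as far as these compounds go, is how a plain phenyl, a 3-chlorophenyl or a ring carrying a nitrile would read on the same sulfonyl sulfur with the core of compound 1, and whether the step would be as large on the core shared by compound 2 and compound 3.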